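Hexafluoro carbinol on the thiazole series: clearance outlook

This account rests on a few compounds, and the source may have more. Where it says the series, first, only, none or still open, it means among the compounds named here.

Compound 3 `CC#C[C@H]1CN(S(=O)(=O)c2ccc(N)nc2)CCN1c1ncc(C(C)(O)C(F)(F)F)s1` sits second highest of the three numbers recorded in an ADME assay (liver) for metabolic stability, with Liver microsome (Rattus norvegicus) as the target, using microsomes and NADPH, with a stated time of 30 min (a lower number here means slower removal, a higher number faster removal of the compound), where compound 3 gives 87 mL.min-1.g-1. Compound 1 `CC#C[C@H]1CN(S(=O)(=O)c2ccc(N)nc2)CCN1c1ccc([C@@](O)(CO)C(F)(F)F)cc1` gives 53 mL.min-1.g-1 in this assay, and the gap between compound 3 and compound 1 lies within the scatter. Compound 2 `CC#C[C@H]1CN(S(=O)(=O)c2ccc(N)nc2)CCN1c1ccc(S(=O)(=O)NCC2CC2)cc1` gives 213 mL.min-1.g-1 in this assay, beyond the scatter from compound 3.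

Compound 4 `CC#C[C@H]1CN(S(=O)(=O)c2ccc(N)nc2)CCN1c1ncc(C(O)(C(F)(F)F)C(F)(F)F)s1` differs from compound 3 by trifluoromethyl in place of methyl on a saturated chain carbon bound to an aromatic carbon, an oxygen on a saturated carbon and a saturated chain carbon.

Within the data shown here, the only single-site step recorded, a 4.0-fold higher number from compound 1 to compound 2 (0.60 log units; beyond the scatter), replaces the whole carbinol side chain with a sulfonamide and therefore does not speak to a methyl-to-trifluoromethyl exchange at the carbinol carbon. Among the measured compounds shown here, no pair of measured compounds carries this exchange, so no direction can be drawn from the data.

With nothing to anchor a shift, compound 4 is expected to stay close to compound 3, the step of a 1.2-fold lower number from compound 3 to compound 4 (0.06 log units; within the scatter) expected to fall within the scatter. For compound 4 the estimate in this assay is 75 mL.min-1.g-1, with a range from 35 mL.min-1.g-1 to 160 mL.min-1.g-1.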

Compound 4, intrinsic clearance in microsomes: 34 mL.min-1.g-1
The estimate for compound 4 lay 2.2-fold (0.34 log units) above the measured number; measured number outside the range, below it.
By their numbers in this assay, from the lowest: compounds 4, 1 and 3 (each within the scatter of the next, the first and the last beyond it); then compound 2.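

Among these compounds, at the carbinol carbon, trifluoromethyl in place of methyl gives a 2.6-fold lower number from compound 3 to compound 4 (0.41 log units; beyond the scatter) in this assay, the first reading of this exchange. The position is therefore not indifferent to the change: with the rest of the molecule held fixed, exchanging this one group moves the clearance number beyond the scatter, whereas the earlier step replaced the whole side chain and could not isolate any effect at this carbon. No available measurement bears on what lies behind the shift.

On these data alone, whether a difluoromethyl group or an ethyl chain on this carbon would give a number near that of the methyl or the trifluoromethyl compound remains open. Also open, as far as these compounds go, are the effect of an amine in place of the hydroxyl and whether the same exchange carries over to the core of compound 1.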